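The source may report more compounds than this note shows. Statements on the series, on what has been measured and on what is new or still open speak of the compounds shown alone.

Measured compounds in the series:
- compound 1, `NC1=NC2(CCOCC2)N(OCCCOc2cccc(Cl)c2)C(N)=N1`, a functional assay on MDA-MB-231 cells (Homo sapiens) for antiproliferative activity, read by MTT assay, with a stated time of 72 h; a higher number here means a weaker inhibitor, a lower number a stronger inhibitor: 1020 nM
- compound 2, `NC1=NC2(CCOCC2)N(OCCCOc2ccc(F)cc2)C(N)=N1`, this assay: "not determined" (no result reported)
- compound 3, `NC1=NC2(CCOCC2)N(OCCCOc2ccc(Cl)cc2)C(N)=N1`, this assay: "not determined" (no result reported)

For the measured compounds named here, compound 3 stands without a number in this assay; the only value belongs to compound 1, which gives 1020 nM. Going by the values given here, compound 2 also carries no result, so compound 3 cannot be placed against any neighbour, and no step between measured compounds is available.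

Compound 4, `NC1=NC2(CCOCC2)N(OCCCOc2cccc(Cl)c2Cl)C(N)=N1`, is to be measured in this assay. It differs from compound 3 in one place: 2,3-dichlorophenyl in place of 4-chlorophenyl on an oxygen on a saturated carbon. The 4-chlorophenyl leaves and the 2,3-dichlorophenyl enters on the oxygen on the saturated carbon, with the shared core untouched.

Among the compounds with values here, with no measured step to lean on, the expectation rests on compound 1 alone, whose 1020 nM is the single anchor for the chlorophenyl ethers in this assay. No shift beyond the scatter is expected in either direction for compound 4 relative to that anchor.

Compound 4 is estimated at 800 nM, with the range 250 nM to 2500 nM.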

Compound 4, half-maximal inhibitory concentration: 140 nM
Estimate against measurement, compound 4: 5.7-fold (0.76 log units) above; the whole stated range lies above it.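

In this assay, chloro in place of hydrogen on an aromatic carbon gives a 7.3-fold lower number from compound 1 to compound 4 (0.86 log units; beyond the scatter) and so moves the number beyond the usual scatter. This shows that the aryl end of the chain is not a silent position: one added chlorine on the ring, with the shared core untouched, is enough to change the antiproliferative read-out, which compound 1 alone could not show. Nothing measured here accounts for this shift.

The change from 4-chlorophenyl to 2,3-dichlorophenyl cannot be read, as compound 3 has no number to set against compound 4. From the compounds shown here alone, whether a trifluoromethyl or methoxy on the ring, or a longer chain to the oxygen, would hold or lose the lower number remains open.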